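Trifluoromethyl in Place of Fluoro: Permeability Outlook

This account rests on a few compounds, and the source may have more. Where it says the series, first, only, none or still open, it means among the compounds named here.

Compound 1 `CNC(=O)c1cc(Oc2ccc3nc(Nc4cccc(OC(F)(F)F)c4)ncc3c2)ccn1` and compound 2 `CNC(=O)c1cc(Oc2ccc3nc(Nc4ccc(F)cc4)ncc3c2)ccn1` share a common core. In an ADME assay on Caco-2 cells (Homo sapiens) for permeability, in the apical to basolateral direction (a higher number here means that the compound crosses the layer faster, a lower number that the compound crosses the layer more slowly), compound 1 gives < 1 10^-6 cm/s, which is a limit of the assay rather than a number. In this assay compound 2 likewise gives < 1 10^-6 cm/s, again a limit and not a number. The step that the two limits leave unreadable from compound 1 to compound 2 therefore cannot be read because the limit of < 1 10^-6 cm/s in this assay, at which 2 of the 2 values shown sit, holds for both values. Compound 3 `CNC(=O)c1cc(Oc2ccc3nc(Nc4ccc(C(F)(F)F)cc4)ncc3c2)ccn1` differs from compound 2 by trifluoromethyl in place of fluoro on an aromatic carbon. Among the compounds with values here, no measured step bears on this change beyond the two limits, and with compound 1 and compound 2 both sitting at the limit of < 1 10^-6 cm/s in this assay, at which 2 of the 2 values shown sit, no direction can be drawn from them. Compound 3 is therefore expected to remain near that limit, the step that the limit leaves unreadable from compound 2 to compound 3 being expected to stay within the scatter. The estimate for compound 3 in this assay is 0.7 10^-6 cm/s, ranging from 0.2 10^-6 cm/s to 2 10^-6 cm/s.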

Compound 3, apparent permeability: < 1 10^-6 cm/s
Compound 3: no number, only a limit; the forecaster's own chance of this, stated with the estimate: 70%; the middle value is on the limit's open side.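

No new step can be read among compound 1, compound 2 and compound 3, because their results in this assay are all limits and not numbers: the limit of < 1 10^-6 cm/s in this assay, at which 3 of the 3 values shown sit.

The compounds shown leave open how far apart these three lie, and whether any change on the shared core would give a readable number in this assay.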